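One methyl on an aromatic nitrogen of compound 2

The source may report more compounds than this note shows. Statements on the series, on what has been measured and on what is new or still open speak of the compounds shown alone.

In a functional assay on Rec1 cells (Homo sapiens) for inhibition, read by MTT assay, with a stated time of 24 h (a higher number here means a weaker inhibitor of growth, a lower number a stronger inhibitor of growth), compound 1 (`Nc1nc(N)c2c(n1)NC(=O)C(c1c(Cl)cccc1Cl)C2`) shows > 100000 nM as a limit, not a number. Among the compounds with values here, compound 2 (`Nc1nc(Nc2ccccc2)nc2[nH]c(=O)c(-c3c(Cl)cccc3Cl)cc12`) gives 12100 nM as the only actual number in this assay so far. Compound 3 (`Cn1c(=O)c(-c2c(Cl)cccc2Cl)cc2c(N)nc(Nc3ccccc3)nc21`) differs from compound 2 by methyl in place of hydrogen on an aromatic nitrogen. Within the data shown here, no measured step shows what such a change does, so a step no larger than the usual scatter, in no clear direction, is expected (a 1.3-fold lower number from compound 2 to compound 3 (0.13 log units; within the scatter)). Compound 3 is estimated at 9000 nM (expected range 2500 nM to 40000 nM).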

Compound 3, concentration for 50% growth inhibition: 1800 nM
Estimate against measurement, compound 3: 5.0-fold (0.70 log units) above; measured number below the stated range.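

Methyl in place of hydrogen on the aromatic nitrogen is the first change here whose size can be read: in this assay it gives a 6.7-fold lower number from compound 2 to compound 3 (0.83 log units; beyond the scatter) and so shows that this nitrogen need not carry a hydrogen for growth inhibition to be kept. Nothing shown here accounts for the size of this step.

From the compounds shown here alone, whether the trend continues beyond methyl stays open, since one step sets no direction for an ethyl group, a longer chain or a chain ending in an amine on this nitrogen.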